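The source may hold more compounds than are shown below. What is called first, only, known or untested is meant among the compounds shown, and "the series" means these compounds.

Measured in a functional assay on A549 cells (Homo sapiens) for cytotoxicity, read by MTT assay, with a stated time of 48 h; a higher number here means a weaker inhibitor, a lower number a stronger inhibitor:
- Compound 1 `O=C(/C=C/c1ccccc1F)Nc1ccc(CC2=CC(=O)OC2)cc1`: 40000 nM
- Compound 2 `C=C1OC(=O)C=C1Cc1ccc(NC(=O)/C=C/c2ccccc2)cc1`: 14800 nM
- Compound 3 `C=C1OC(=O)C=C1Cc1ccc(NC(=O)/C=C/c2cccc(F)c2)cc1`: 35200 nM

Compound 3 lies within the scatter of compound 1, and its gap to the other compound is a 2.4-fold higher number from compound 2 to compound 3 (0.38 log units; beyond the scatter). Compound 4 `C=C1OC(=O)C=C1Cc1ccc(NC(=O)/C=C/c2ccccc2F)cc1` keeps the same atoms and only moves the fluorine: 2-fluorophenyl in place of 3-fluorophenyl on a double-bonded chain carbon bound to a double-bonded chain carbon.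

Within the data shown here, the one measured step that bears on this change is the modest 2.4-fold higher number from compound 2 to compound 3 (0.38 log units; beyond the scatter). Among the measured compounds shown here, that step added a fluorine, whereas compound 4 keeps one, and no measured pair shows a fluorine moving. Little change is therefore expected, with no step beyond the scatter in this assay. The expected step is a 1.2-fold lower number from compound 3 to compound 4 (0.07 log units; within the scatter). For compound 4 the estimated value is 30000 nM, with an expected range of 14000 nM to 60000 nM.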

Compound 4, half-maximal inhibitory concentration: 7410 nM
Compound 4: middle estimate off by 4.0-fold (0.61 log units), on the high side; the measured number lies below the stated range.
By their numbers in this assay, from the lowest: compounds 4 and 2 (each within the scatter of the next); then compounds 3 and 1 (each within the scatter of the next).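

In this assay, the place of the fluorine counts even when the atoms stay the same: 2-fluorophenyl in place of 3-fluorophenyl gives a 4.8-fold lower number from compound 3 to compound 4 (0.68 log units; beyond the scatter) in this series. Fluoro in place of hydrogen therefore need not raise the number, as a 2.0-fold lower number from compound 2 to compound 4 (0.30 log units; within the scatter) shows no change beyond the scatter. With 2-fluorophenyl kept, the group on the saturated chain carbon also counts, giving a 5.4-fold lower number from compound 1 to compound 4 (0.73 log units; beyond the scatter) for that single change.

Going by these compounds, how 2-chlorophenyl or 2-methoxyphenyl would behave at this place remains open. No available evidence explains the effect of moving the fluorine.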